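Sulfoxide amides: cytotoxicity outlook for the trimethylphenyl analogue

The source may report more compounds than this note shows. Statements on the series, on what has been measured and on what is new or still open speak of the compounds shown alone.

Within the data shown here, compound 2 `COc1cc2nc([S+]([O-])CC(=O)Nc3cccc(C(F)(F)F)c3)nc(Nc3c(Cl)cc(/C=C/C#N)cc3Cl)c2cc1OC` gives 21800 nM in an ADME assay on MT4 cells (Homo sapiens) for cytotoxicity, read by MTT assay, with a stated time of 5 days (a higher number here means that more compound is tolerated, a lower number that less compound is tolerated), and is the only compound of the pair with a numerical value there. Compound 1 `COc1cc2nc(SCC(=O)Nc3ccc(F)cc3)nc(Nc3c(C)cc(/C=C/C#N)cc3C)c2cc1OC` reaches only a limit of the assay, >= 150000 nM in this assay, consistent with the limit of >= 150000 nM in this assay, at which 1 of the 2 values shown sits. Among the measured compounds shown here, compound 3 `COc1cc2nc([S+]([O-])CC(=O)Nc3c(C)cc(C)cc3C)nc(Nc3c(Cl)cc(/C=C/C#N)cc3Cl)c2cc1OC` carries 2,4,6-trimethylphenyl in place of 3-(trifluoromethyl)phenyl on an amide-type nitrogen; no measured step of this kind exists, so the expectation rests on compound 2 alone. A step no larger than the usual scatter is expected, with the wide uncertainty that such a change warrants, so for compound 3 the expected step is a 1.4-fold higher number from compound 2 to compound 3 (0.14 log units; within the scatter). Compound 3 is therefore estimated at 30000 nM in this assay, within 8000 nM to 150000 nM.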

Compound 3, half-maximal cytotoxic concentration: 8870 nM
Compound 3: the middle estimate sits 3.4-fold (0.53 log units) above what was measured; measured number inside the range.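

In this assay, the aryl group on the amide-type nitrogen affects tolerated concentration: 2,4,6-trimethylphenyl in place of 3-(trifluoromethyl)phenyl gives a 2.5-fold lower number from compound 2 to compound 3 (0.39 log units; beyond the scatter). Among these compounds, this is the only readable step, as compound 1 differs from both other compounds in more than one place. Nothing shown here accounts for its direction.

As far as these compounds go, it remains open whether a pyridine ring or a simple alkyl chain on this nitrogen would shift the number further. A single step also cannot show whether the change behaves the same way with other groups elsewhere on the shared core.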